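Ethoxy in Place of Benzyloxy on the Shared Core

This account rests on a few compounds, and the source may have more. Where it says the series, first, only, none or still open, it means among the compounds named here.

Compound 1 `COc1cc2c(c(O)c1OC)C(=O)[C@]1(OC)C=C[C@H]2N(C(=O)OCC(C)C)N1C(=O)OCC(C)C`: in an ADME assay on KB cells (Homo sapiens) for cytotoxicity (a higher number here means that more compound is needed for the effect, a lower number that less compound is needed), compound 1 gives > 300 ug/mL, a limit of the assay.
Compound 2 `COc1ccc(COc2c(OC)c(OC)cc3c2C(=O)[C@]2(OC)C=C[C@H]3N(C(=O)OCC(C)C)N2C(=O)OCC(C)C)cc1`: in this assay compound 2 gives 47.9 ug/mL.
Compound 3 `COc1cc2c(c(OCc3ccccc3)c1OC)C(=O)[C@]1(OC)C=C[C@H]2N(C(=O)OCC(C)C)N1C(=O)OCC(C)C`: in this assay compound 3 gives 94 ug/mL.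

Compound 3 holds the higher of the two numbers, with compound 2 nearest: a 2.0-fold higher number from compound 2 to compound 3 (0.29 log units; within the scatter). Compound 4 `CCOc1c(OC)c(OC)cc2c1C(=O)[C@]1(OC)C=C[C@H]2N(C(=O)OCC(C)C)N1C(=O)OCC(C)C` differs from compound 3 by methyl in place of phenyl on a saturated chain carbon bound to an oxygen on an aromatic ring. The step that bears on this is an at least 3.1-fold lower number from compound 1 to compound 3 (0.50 log units; beyond the scatter), where compound 1 sat at the limit of > 300 ug/mL in this assay, at which 1 of the 3 values shown sits. Taking the phenyl away again is therefore expected to move the number part of the way back upward, and the step of a 1.9-fold higher number from compound 3 to compound 4 (0.28 log units; within the scatter) is expected to be modest in that direction. For compound 4 the expected value in this assay is 180 ug/mL, within a range of 70 ug/mL to 400 ug/mL.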

Compound 4, concentration for half-maximal effect: > 300 ug/mL
Compound 4: no number, only a limit; the forecaster's own chance of this, stated with the estimate: 25%; middle value at least 1.6-fold (0.22 log units) away from the limit.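

Putting a group on this oxygen is not enough in itself: with methyl in place of phenyl, this assay gives an at least 3.1-fold higher number from compound 3 to compound 4 (0.50 log units; beyond the scatter), and with methyl in place of 4-methoxyphenyl, an at least 6.2-fold higher number from compound 2 to compound 4 (0.79 log units; beyond the scatter). Among the compounds shown, the lower numbers therefore go with the benzyl and 4-methoxybenzyl groups and not with ethyl. The step from compound 1 to compound 4 cannot be read: the limit of > 300 ug/mL in this assay, at which 2 of the 4 values shown sit.

From the compounds shown here alone, it stays open whether a longer chain such as butyl, or cyclohexylmethyl with its saturated ring, would give a lower number on this oxygen. Going by these compounds, the effect of an amine or a carboxylic acid on the benzyl ring also stays open.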